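From Fluoro to Bromo: Little Change Expected

The source may report more compounds than this note shows. Statements on the series, on what has been measured and on what is new or still open speak of the compounds shown alone.

Compound 2 `COc1cc2c(Oc3ccc(NC(=O)c4nn(-c5ccccc5F)c(=O)c5ccccc45)cc3F)ccnc2cc1OCCCN1CCN(C)CC1` holds the highest of the two numbers recorded so far. In a functional assay on MDA-MB-231 cells (Homo sapiens) for cytotoxicity, read by MTT assay, with a stated time of 72 h (on this read-out higher numbers stand for weaker inhibition and lower numbers for stronger inhibition), compound 2 gives 1050 nM, while compound 1 `COc1cc2c(Oc3ccc(NC(=O)c4nn(-c5ccccc5Br)c(=O)c5ccccc45)cc3F)ccnc2cc1OCCCN1CCCC1` gives 1020 nM; the two values lie within the scatter of each other. Compound 3 `COc1cc2c(Oc3ccc(NC(=O)c4nn(-c5ccccc5Br)c(=O)c5ccccc45)cc3F)ccnc2cc1OCCCN1CCN(C)CC1` has not yet been measured. Relative to compound 2 it carries bromo in place of fluoro on an aromatic carbon. Going by the values given here, no measured step covers this change, so no movement beyond the scatter is expected, and the step of a 1.1-fold lower number from compound 2 to compound 3 (0.02 log units; within the scatter) is estimated to be essentially flat. Compound 3 is therefore expected to give about 1000 nM, with a range from 400 nM to 2500 nM.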

Compound 3, half-maximal inhibitory concentration: 1680 nM
Compound 3: middle estimate off by 1.7-fold (0.23 log units), on the low side, within the range that was stated.
By their numbers in this assay, from the lowest: compounds 1, 2 and 3 (each within the scatter of the next).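

The 2-fluorophenyl to 2-bromophenyl change now has a measured step in this assay, namely a 1.6-fold higher number from compound 2 to compound 3 (0.20 log units; within the scatter), so at this place the larger halogen does not move the number beyond the scatter. With bromo held constant, 4-methylpiperazin-1-yl in place of pyrrolidin-1-yl on the chain gives a 1.6-fold higher number from compound 1 to compound 3 (0.22 log units; within the scatter), so neither single change separates these compounds on this read-out. Nothing shown here offers an account of either step.

Going by these compounds, whether chloro, methoxy or plain hydrogen on that aromatic carbon would stay equally flat remains open. So does the outcome of a morpholin-4-yl group at the chain end.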